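From Compound 1 to Compound 3: One Ring Exchanged

The source may report more compounds than this note shows. Statements on the series, on what has been measured and on what is new or still open speak of the compounds shown alone.

Within the data shown here, in a functional assay on MIA PaCa-2 cells (Homo sapiens) for inhibition, read by MTT assay, with a stated time of 72 h (a lower number here means a stronger inhibitor, a higher number a weaker inhibitor), compound 1 `Cc1cnc(C(=O)Nc2cc(F)cc3cccnc23)cn1` gives 310 nM, the lower of the two numbers so far, while compound 2 `Cc1cnc(C(=O)Nc2cc(Cl)cc3cccnc23)cn1` gives 1500 nM. Compound 3 `O=C(Nc1cc(F)cc2cccnc12)c1ncccn1` has not been measured. It carries pyrimidin-2-yl in place of 5-methylpyrazin-2-yl on a carbonyl carbon. Among the measured compounds shown here, the only measured step, a 4.8-fold higher number from compound 1 to compound 2 (0.68 log units; beyond the scatter), is a modest one and comes from a different change, chloro in place of fluoro, so it guides size only. A similarly modest rise is expected, though its direction is uncertain. The estimated step is a 2.3-fold higher number from compound 1 to compound 3 (0.35 log units; beyond the scatter). For compound 3, the expected value is 700 nM, within a range of 180 nM to 2800 nM.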

Compound 3, half-maximal inhibitory concentration: 300 nM
For compound 3 the middle estimate is 2.3-fold (0.37 log units) above the measured one, and the stated range covers the measured number.
By their numbers in this assay, from the lowest: compounds 3 and 1 (each within the scatter of the next); then compound 2.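

In this assay the exchange of 5-methylpyrazin-2-yl for pyrimidin-2-yl on a carbonyl carbon gives a 1.0-fold lower number from compound 1 to compound 3 (0.01 log units; within the scatter) and so leaves the number unchanged within the scatter. The earlier pair showed only a change on the shared core, whereas this step shows that this other place can hold either of these two rings in this assay. Nothing measured here explains this match.

Still open, from the compounds shown here alone, is how a phenyl ring or a saturated amine such as morpholine would fare on that carbonyl carbon. Also open, going by these compounds, is whether chloro in place of fluoro would give a similar step with pyrimidin-2-yl present.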